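The compounds below may be only part of what the source reports. "The series", "measured", "known", "first", "only" and "open" are said of these compounds alone.

Measured compounds: compound 1 `O=C(Nc1cc(C(F)(F)F)ccc1Nc1ccc(Br)cc1)c1ccccc1` with 33800 nM; compound 2 `O=C(Nc1cc(C(F)(F)F)ccc1N1CCCC1)c1ccncc1` with "not active" (no number reported); compound 3 `O=C(Nc1cc(C(F)(F)F)ccc1NC1CCCCC1)c1ccccc1` with "not active" (no number reported).

Among the measured compounds shown here, in a functional assay on Jurkat cells (Homo sapiens) for cytotoxicity, read by MTT assay, with a stated time of 48 h (a lower number here means a stronger inhibitor, a higher number a weaker inhibitor), compound 1 gives 33800 nM, the only number among the three. Compound 2 is reported as "not active" (no number reported) in this assay, and compound 3 likewise as "not active" (no number reported), so compound 3 stands among the entries without a number. Compound 4 `O=C(Nc1cc(C(F)(F)F)ccc1N1CCCC1)c1ccccc1` has not been measured. It differs from compound 3 by pyrrolidin-1-yl in place of cyclohexylamino on an aromatic carbon, the change sitting para to a trifluoromethyl group. For the measured compounds named here, no measured step spans this change, and compound 2, which carries the entering group, is also "not active" (no number reported). Compound 4 is therefore expected to remain weak, with an estimated value of 60000 nM, in a range from 20000 nM to 200000 nM.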

Compound 4, half-maximal inhibitory concentration: "not active" (no number reported)
Compound 4 has no reported number here; no gap can be computed for the estimate.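

Compound 3 and compound 4 are both reported as not active in this assay without a number, so no step can be read between them, and no available evidence bears on this result. The compounds shown leave open whether pyrrolidin-1-yl in place of cyclohexylamino changes activity at all.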